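The source may report more compounds than this note shows. Statements on the series, on what has been measured and on what is new or still open speak of the compounds shown alone.

Measured compounds: in an assay (strain Sprague-Dawley) for inhibition of Amine oxidase [flavin-containing] B (Rattus norvegicus), read by spectrophotometry, with a stated time of 5 min, tested at 10 uM (on this read-out lower numbers stand for less inhibition and higher numbers for more inhibition at the one concentration tested (going by the name of the read-out)), compound 1 `CNC(=O)/C=C1/COc2c1ccc(OS(=O)(=O)c1ccccc1)c2C` gives 5%. Compound 2 `CNC(=O)/C=C1/COc2c1ccc(OS(=O)(=O)c1cccc(Cl)c1)c2C` gives 2%. Compound 3 `CNC(=O)/C=C1/COc2c1ccc(OS(=O)(=O)c1ccc(C#N)cc1)c2C` gives 6%.

Compound 3 carries the highest of the three numbers, but only narrowly: a number 1 percentage points higher from compound 1 to compound 3 (within the scatter) and a number 4 percentage points higher from compound 2 to compound 3 (within the scatter), so none of the three is separated from another beyond the scatter. Compound 4 `CNC(=O)/C=C1/COc2c1ccc(OS(=O)(=O)c1ccc(OC)cc1)c2C` differs from compound 3 in one place: methoxy in place of cyano on an aromatic carbon. Among the compounds with values here, the steps that bear on this exchange at the sulfonyl aryl ring are a number 3 percentage points lower from compound 1 to compound 2 (within the scatter), a number 1 percentage points higher from compound 1 to compound 3 (within the scatter) and a number 4 percentage points higher from compound 2 to compound 3 (within the scatter); each of them stays inside the scatter, and all three aryl variations leave inhibition low. Compound 4 is therefore expected to show a number 1 percentage points lower from compound 3 to compound 4 (within the scatter), no step beyond the scatter in this assay. The estimate for compound 4 is 5%, expected between 0% and 15%.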

Compound 4, a percentage reported as inhibition, at one concentration (the size of the read-out at that concentration, not a potency): 0%
The estimate for compound 4 lay 5 percentage points above the measured number, within the range that was stated.
By their numbers in this assay, from the lowest: compounds 4, 2, 1 and 3 (each within the scatter of the next).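

In this assay, methoxy on this aromatic carbon stays within the scatter of cyano (a number 6 percentage points lower from compound 3 to compound 4 (within the scatter)), of the 3-chlorophenyl variant (a number 2 percentage points lower from compound 2 to compound 4 (within the scatter)) and of hydrogen (a number 5 percentage points lower from compound 1 to compound 4 (within the scatter)). An oxygen-linked group at this place thus leaves the number as undistinguished as the nitrile did, so no aryl variation shown separates from another. Nothing available explains this result. As far as these compounds go, whether an amine or a carboxylic acid on this ring would give a step beyond the scatter remains open, as does the effect of a longer alkyl chain in place of the aryl ring on the sulfonyl sulfur.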